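Carbamate Ring Size and Amine Oxidase A Inhibition

This account rests on a few compounds, and the source may have more. Where it says the series, first, only, none or still open, it means among the compounds named here.

Compound 1 `CCN(CC)C(=O)Oc1ccc(C(=O)/C=C/c2ccc(N(C)C)cc2)c(O)c1`: 24.4%
Compound 2 `CN(C)c1ccc(/C=C/C(=O)c2ccc(OC(=O)N3CCCC3)cc2O)cc1`: 12.8%

In an assay on cells for inhibition of Amine oxidase [flavin-containing] A (Homo sapiens), read by fluorescence, with a stated time of 30 min, tested at 10 uM (a lower number here means less inhibition, a higher number more inhibition at the concentration tested (going by the name of the read-out)), compound 1 gives 24.4% and compound 2 gives 12.8%. Going by the values given here, compound 2 therefore stands lowest of the two numbers; its nearest neighbour, compound 1, lies higher, and that one measured step, a number 11.6 percentage points lower from compound 1 to compound 2 (beyond the scatter), is the only step that bears on the next change. Compound 3 `CN(C)c1ccc(/C=C/C(=O)c2ccc(OC(=O)N3CCCCC3)cc2O)cc1` differs from compound 2 by piperidin-1-yl in place of pyrrolidin-1-yl on a carbonyl carbon. Since exchanging one amine on that carbonyl for another moved the read-out only modestly, the step of a number 1.2 percentage points higher from compound 2 to compound 3 (within the scatter) is expected to stay within the scatter, with little direction. Compound 3 is estimated at 14%, between 4% and 28%.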

Compound 3, a percentage reported as inhibition, at one concentration (the size of the read-out at that concentration, not a potency): 27.8%
Estimate against measurement, compound 3: 13.8 percentage points below; low and high end bracket the measured number.
By their numbers in this assay, from the lowest: compound 2; then compounds 1 and 3 (each within the scatter of the next).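

Exchanging pyrrolidin-1-yl for piperidin-1-yl on the carbonyl carbon gives a number 15 percentage points higher from compound 2 to compound 3 (beyond the scatter), so the read-out in this assay depends on which ring stands at this position. Piperidin-1-yl and diethylamino cannot be told apart, with a number 3.4 percentage points higher from compound 1 to compound 3 (within the scatter), and among these three groups only pyrrolidin-1-yl stands apart. No measurement shown accounts for this difference. Still open, going by these compounds, is how a morpholin-4-yl or azepan-1-yl group on the same carbonyl carbon would read in this assay.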